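The source may hold more compounds than are shown below. What is called first, only, known or untested is meant among the compounds shown, and "the series" means these compounds.

Three ethers of the shared core have been read so far in a functional assay on PC-3 cells (Homo sapiens) for antiproliferative activity, read by WST assay, with a stated time of 3 days (a lower number here means a stronger inhibitor, a higher number a weaker inhibitor), and there compound 1 `CCCCCCOc1c(-c2cc(OC)c(OC)c(OC)c2)oc2ccccc2c1=O` gives 29200 nM and compound 2 `CCCC(C)Oc1c(-c2cc(OC)c(OC)c(OC)c2)oc2ccccc2c1=O` gives 49300 nM while compound 3 `CCN(CC)CCCOc1c(-c2cc(OC)c(OC)c(OC)c2)oc2ccccc2c1=O` gives 13600 nM as the lowest of the three numbers. Compound 4 `CCCN(CCC)CCCOc1c(-c2cc(OC)c(OC)c(OC)c2)oc2ccccc2c1=O` has dipropylamino in place of diethylamino on a saturated chain carbon, three bonds along the chain from an oxygen on an aromatic ring. The closest evidence is indirect: a 2.1-fold lower number from compound 1 to compound 3 (0.33 log units; beyond the scatter) and a 3.6-fold lower number from compound 2 to compound 3 (0.56 log units; beyond the scatter) are modest, and a 1.7-fold higher number from compound 1 to compound 2 (0.23 log units; within the scatter) stays within the scatter. Among the compounds with values here, no measured step alters the groups on that nitrogen, so the expected step, a 1.0-fold lower number from compound 3 to compound 4 (0.02 log units; within the scatter), lies within the scatter. For compound 4 the estimate is 13000 nM with an expected range of 6000 nM to 30000 nM.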

Compound 4, half-maximal inhibitory concentration: 16800 nM
Estimate against measurement, compound 4: 1.3-fold (0.11 log units) below; the measured number falls inside the stated range.
By their numbers in this assay, from the lowest: compounds 3, 4, 1 and 2 (each within the scatter of the next, the first and the last beyond it).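

Dipropylamino in place of diethylamino, the first change shown on that nitrogen, gives a 1.2-fold higher number from compound 3 to compound 4 (0.09 log units; within the scatter) and so does not separate the two amines. The branched ether stays apart, with a 2.9-fold lower number from compound 2 to compound 4 (0.47 log units; beyond the scatter) for the dipropylamino compound, whereas a 1.7-fold lower number from compound 1 to compound 4 (0.24 log units; within the scatter) does not separate that compound from the hexyl ether, a separation the diethylamino compound did reach.

Going by these compounds, whether a ring amine such as piperidine or morpholine on the same chain, or the shorter 2-(diethylamino)ethyl group, would move the number stays open. No accompanying measurement offers an explanation for this result.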